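The source may report more compounds than this note shows. Statements on the series, on what has been measured and on what is new or still open speak of the compounds shown alone.

In a functional assay on the whole organism for inhibition, with Cavia porcellus as the target (a lower number here means that less compound is needed, a higher number that more compound is needed for the effect), compound 1 `COc1ccccc1OCC1SCCN1C(C)=O` gives 46 mg/kg, compound 2 `COc1ccccc1OCC1SCCN1C(=O)CC(C)=O` gives 30 mg/kg and compound 3 `COc1ccccc1OCC1N(C(=O)CC(=O)O)CC[S+]1[O-]` gives 20 mg/kg. Compound 2 therefore holds the middle of the three numbers, within the scatter of each of the other two. Compound 4 `CCOC(=O)C(C)(C)C(=O)N1CCSC1COc1ccccc1OC` has 1-(ethoxycarbonyl)-1-methylethyl in place of 2-oxopropyl on a carbonyl carbon. Among the compounds with values here, no measured compound carries the entering group. Within the data shown here, the one measured step bearing on this change is a 1.5-fold lower number from compound 1 to compound 2 (0.19 log units; within the scatter), a single pair that offers only weak guidance. No shift beyond the scatter is therefore expected in this assay. The expected step is no change at the digits printed from compound 2 to compound 4 (within the scatter). Compound 4 is estimated at 30 mg/kg, with an expected range of 12 mg/kg to 70 mg/kg.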

Compound 4, dose for half-maximal effect: 61 mg/kg
The estimate for compound 4 lay 2.0-fold (0.31 log units) below the measured number; the range from low to high includes it.
By their numbers in this assay, from the lowest: compounds 3, 2, 1 and 4 (each within the scatter of the next, the first and the last beyond it).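

Within the data shown here, on this carbonyl carbon, 1-(ethoxycarbonyl)-1-methylethyl in place of 2-oxopropyl gives the first step beyond the scatter, with a 2.0-fold higher number from compound 2 to compound 4 (0.31 log units; beyond the scatter), though only a modest one. Set against methyl, the same group stays within the scatter, with a 1.3-fold higher number from compound 1 to compound 4 (0.12 log units; within the scatter), so it is separated from 2-oxopropyl but not from methyl. Nothing on hand gives a reason for either step.

The ester and the branching enter together, and the compounds shown do not separate them. From the compounds shown here alone, how an amine or a longer unbranched chain on this carbonyl carbon would read also remains open.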